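From phenyl to pyridin-3-yl on compound 3

This account rests on a few compounds, and the source may have more. Where it says the series, first, only, none or still open, it means among the compounds named here.

Results so far in a toxicity assay on NIH3T3 cells (Mus musculus) for cytotoxicity, read by resazurin assay; a lower number here means that less compound is needed, a higher number that more compound is needed for the effect:
Compound 1 `c1ccc(Cn2cncc2CNc2cccc(-c3ccncc3)c2)cc1` gives > 1000 nM as a limit
Compound 2 `Cc1cccc(-c2cccc(NCc3cncn3Cc3ccccc3)c2)c1` gives > 1000 nM as a limit
Compound 3 `c1ccc(Cn2cncc2CNc2cccc(-c3ccccc3)c2)cc1` gives > 750 nM as a limit

Within the data shown here, no measured compound here has a number, so compound 3 can be placed only by its limit. In this assay compound 3 stands at > 750 nM and that is a limit. Compound 4 `c1ccc(Cn2cncc2CNc2cccc(-c3cccnc3)c2)cc1` carries pyridin-3-yl in place of phenyl on an aromatic carbon, and the change is counted as follows: pyridin-3-yl in place of phenyl on an aromatic carbon.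

Among the measured compounds shown here, three measured steps bear on this change. The closest, phenyl in place of pyridin-4-yl, is a step that the two limits leave unreadable from compound 1 to compound 3 and gives no size. The 3-methylphenyl change is a step that the two limits leave unreadable from compound 1 to compound 2 and the loss of the methyl is a step that the two limits leave unreadable from compound 2 to compound 3, so neither gives a size either. With a step that the two limits leave unreadable from compound 1 to compound 3 as the nearest guide, no step beyond the scatter and no direction is expected in this assay for this change. The expected step is a step that the limit leaves unreadable from compound 3 to compound 4 on this estimate. Compound 4 is estimated at 1200 nM with an expected range from 600 nM to 3000 nM when measured, and a limit is the likeliest result.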

Compound 4, half-maximal effective concentration: > 1000 nM
Compound 4: a limit, no number; the forecaster's own chance of this, stated with the estimate: 80%; the middle value does not contradict the limit.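

In this assay compound 4 gives > 1000 nM, which is a limit. Among these compounds, no step from compound 1, compound 2 or compound 3 to compound 4 can be read. The compounds shown leave open whether pyridin-3-yl, pyridin-4-yl, phenyl and 3-methylphenyl differ at all in this assay.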